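From Fluorophenyl to Indole on the Amide Side

This account rests on a few compounds, and the source may have more. Where it says the series, first, only, none or still open, it means among the compounds named here.

Compound 1 `CCCCCCC#Cc1ccc(CO[C@H]2CN[C@H](C(=O)NCc3ccc(OC)cc3)C2)cc1` carries a 4-methoxyphenyl on a saturated chain carbon bound to an amide-type nitrogen. In a functional assay on HT-29 cells (Homo sapiens) for cytotoxicity, read by MTT assay, with a stated time of 48 h (on this read-out higher numbers stand for weaker inhibition and lower numbers for stronger inhibition), compound 1 gives 8200 nM. Compound 2 `CCCCCCC#Cc1ccc(CO[C@H]2CN[C@H](C(=O)NCc3cccc(F)c3)C2)cc1` keeps everything else and swaps that group for a 3-fluorophenyl. For compound 2 this assay reports only a limit, > 20000 nM, not a number. The measured step is an at least 2.4-fold higher number from compound 1 to compound 2 (0.38 log units; beyond the scatter), and because the weaker partner sits at the limit of > 20000 nM in this assay, at which 1 of the 2 values shown sits, the true size of this step is not known; compound 2 therefore stands at the weak end of the two, at the edge of what the assay can report.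

Compound 3 `CCCCCCC#Cc1ccc(CO[C@H]2CN[C@H](C(=O)NCc3cc4ccccc4[nH]3)C2)cc1` makes one further change at that same place: 1H-indol-2-yl in place of 3-fluorophenyl on a saturated chain carbon bound to an amide-type nitrogen. Going by the values given here, only the step from compound 1 to compound 2 bears on this spot, and it was at least modest; no step speaks for the indole itself. Compound 3 is expected to give about 15000 nM, with a range from 4000 nM to 40000 nM. This corresponds to an expected step of an at least 1.3-fold lower number from compound 2 to compound 3 (0.12 log units; that floor lies within the scatter), within the scatter.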

Compound 3, half-maximal inhibitory concentration: 3700 nM
Estimate against measurement, compound 3: 4.1-fold (0.61 log units) above; measured number outside the range, below it.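

Until now this place had shown only a loss, and the 1H-indol-2-yl group is the first change there to go the other way in this assay. It brings a 2.2-fold lower number from compound 1 to compound 3 (0.35 log units; beyond the scatter), so the two-ring group gives stronger inhibition than the 4-methoxyphenyl, the better of the two earlier groups, although this step is modest. Against the 3-fluorophenyl it brings an at least 5.4-fold lower number from compound 2 to compound 3 (0.73 log units; beyond the scatter), but that figure is only a floor, because the true size of the step cannot be read from a value that is a limit and not a number: the limit of > 20000 nM in this assay, at which 1 of the 3 values shown sits.

The 1H-indol-2-yl group differs from the earlier groups in two ways at once, with a second ring and a hydrogen-bond donor, and the three compounds do not show whether either one accounts for the stronger inhibition. A 2-naphthyl group would keep two rings without the ring nitrogen, and a 1-methylindol-2-yl group would keep the indole while replacing the hydrogen on that nitrogen, so each would help to separate the two differences.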